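Thioether Tail: From Aminoethyl to Hydroxycyclopentyl

The compounds below may be only part of what the source reports. "The series", "measured", "known", "first", "only" and "open" are said of these compounds alone.

Compound 2 `CC(C)c1n[nH]c2c(NCc3ccc(-c4ccccn4)cc3)nc(SCCN)nc12` holds the lowest of the two numbers at hand: in a functional assay on HT cells (Homo sapiens) for antiproliferative activity, read by fluorescence, with a stated time of 72 h (on this read-out higher numbers stand for weaker inhibition of growth and lower numbers for stronger inhibition of growth), compound 2 gives 22 nM, while compound 1 `CC(C)c1n[nH]c2c(NCc3ccc(-c4ccccn4)cc3)nc(SCC(O)CN)nc12` gives 55 nM. Within the data shown here, the only measured step, a 2.5-fold lower number from compound 1 to compound 2 (0.40 log units; beyond the scatter), is a modest gain as 2-amino-1-hydroxyethyl gives way to aminomethyl. Compound 3 `CC(C)c1n[nH]c2c(NCc3ccc(-c4ccccn4)cc3)nc(SC3CCCC3O)nc12` carries the change (2-hydroxycyclopentyl in place of 2-aminoethyl on a sulfur). That earlier step bears only loosely here: a hydroxyl enters again, now in a five-membered ring, and the nitrogen leaves entirely, so a modest rise in the number is expected, a 3.6-fold higher number from compound 2 to compound 3 (0.56 log units; beyond the scatter). Compound 3 is therefore estimated at 80 nM, within 25 nM to 260 nM.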

Compound 3, concentration for 50% growth inhibition: 567 nM
Compound 3: middle estimate off by 7.1-fold (0.85 log units), on the low side, and the stated range ends below it.
By their numbers in this assay, from the lowest: compound 2; then compound 1; then compound 3.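

Among these compounds, the sulfur substituent proves far more sensitive than the one earlier step suggested: 2-hydroxycyclopentyl in place of 2-aminoethyl gives a 26-fold higher number from compound 2 to compound 3 (1.41 log units; beyond the scatter), and the same group in place of 3-amino-2-hydroxypropyl gives a 10-fold higher number from compound 1 to compound 3 (1.01 log units; beyond the scatter), both large steps. Both open chains bearing an amine thus stand well ahead of the hydroxylated ring. Nothing at hand accounts for this loss. The nitrogen and the ring changed together, so the compounds shown do not separate the two. A 2-aminocyclopentyl group or a 2-hydroxyethyl chain on the same sulfur would.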